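Moving the methoxy group on a sulfonamide-benzamide series

A few compounds are considered here, and "the series" means these few. Any claim that something is new, unique, unknown or untested is made for them only; others in the source may bear on it.

Compound 1 `COc1ccc(-c2cccc(C(=O)N(C)C)c2)cc1S(=O)(=O)Nc1ccc2cccc(NC(=O)c3ccccc3)c2c1` gives 31.8% in a functional assay on CHO cells for agonist activity at Orexin/Hypocretin receptor type 1 (Homo sapiens); a higher number here means a larger maximal response, a lower number a smaller maximal response. As far as these compounds go, compound 2 `COc1ccccc1C(=O)N(C)c1cccc2ccc(NS(=O)(=O)c3cc(-c4cccc(C(=O)N(C)C)c4)ccc3OC)cc12` shares the sulfonamide part of that core but carries a methylated amide, and in this assay compound 2 is recorded as "nd" (no result reported), so its standing is unknown. Compound 3 `COc1cccc(C(=O)N(C)c2cccc3ccc(NS(=O)(=O)c4cc(-c5cccc(C(=O)N(C)C)c5)ccc4OC)cc23)c1` is the next compound: 3-methoxyphenyl in place of 2-methoxyphenyl on a carbonyl carbon. Going by the values given here, with no measured step between compound 2 and compound 3, the size and direction of the change in this assay cannot be read from the numbers; a shift no larger than the usual scatter is the plain expectation. The maximal response of compound 3 is estimated at 30%, within 10% to 55%.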

Compound 3, largest response reached (Emax), in percent of the reference or control that the assay uses: 101%
Beside the measured number, compound 3's estimate is 71 percentage points below it; the whole stated range lies below it.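

In this assay, ((3-methoxyphenyl)carbonyl)(methyl)amino in place of benzamido on an aromatic carbon gives a number 69.2 percentage points higher from compound 1 to compound 3 (beyond the scatter), so this place on the shared core can strongly change the maximal response. The step from compound 2 cannot be read, as compound 2 has no number. No data on the cause of this gain are available.

As far as these compounds go, it remains open whether the methoxy group, the methyl on the amide nitrogen or both together account for the gain. Also open, from the compounds shown here alone, is how an amine or a carboxylic acid in place of the methoxy group would fare.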